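Trifluoropropyl for oxolanyl on the Core Ring Nitrogen

The source may report more compounds than this note shows. Statements on the series, on what has been measured and on what is new or still open speak of the compounds shown alone.

Measured compounds:
compound 1, `CC[C@@H]1C(=O)N(C)c2cnc(-n3ccnc3-c3ccc(F)cc3)nc2N1[C@H]1CCOC1`, 2050 nM
compound 2, `CC[C@@H]1C(=O)N(C)c2cnc(-c3cn[nH]c3-c3nccs3)nc2N1[C@H]1CCOC1`, 3190 nM

Among the measured compounds shown here, the two compounds measured so far were tested in an assay on HEK293 cells for inhibition of serine/threonine-protein kinase PLK2 (Homo sapiens), read by ELISA, with a stated time of 2 h; a lower number here means a stronger inhibitor, a higher number a weaker inhibitor. Compound 1 gives 2050 nM, the lowest of the two numbers recorded, but its nearest neighbour, compound 2, gives 3190 nM, and the gap between the two lies within the scatter of repeated measurements, so neither can be called the stronger inhibitor on these data alone. For the measured compounds named here, compound 2 also differs from compound 1 in more than one place, so no single-point step between measured compounds is available.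

Compound 3, `CC[C@@H]1C(=O)N(C)c2cnc(-n3ccnc3-c3ccc(F)cc3)nc2N1CCC(F)(F)F`, has not yet been measured in this assay. It differs from compound 1 in one place: 3,3,3-trifluoropropyl in place of oxolan-3-yl on a nitrogen on an aromatic ring in a ring. Going by the values given here, with no measured step of this kind to lean on, the size of the effect is open, and the account here expects a change from compound 1 to compound 3 of a 1.5-fold higher number from compound 1 to compound 3 (0.17 log units; within the scatter), that is, no shift clearly beyond the scatter. On that basis compound 3 is estimated at 3000 nM in this assay, with a likely range from 1000 nM to 9000 nM.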

Compound 3, half-maximal inhibitory concentration in the serine/threonine-protein kinase PLK2 assay: 2560 nM
For compound 3 the middle estimate is 1.2-fold (0.07 log units) above the measured one, within the range that was stated.
By their numbers in the serine/threonine-protein kinase PLK2 assay, from the lowest: compounds 1, 3 and 2 (each within the scatter of the next).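

In the serine/threonine-protein kinase PLK2 assay, exchanging oxolan-3-yl for 3,3,3-trifluoropropyl on this nitrogen gives a 1.2-fold higher number from compound 1 to compound 3 (0.10 log units; within the scatter), so at this position the ring, the defined stereocentre and the hydrogen-bond acceptor of oxolan-3-yl can all be given up without a shift beyond the scatter. Among the compounds shown here, in a physicochemical assay for lipophilicity (a lower number here means a more polar compound, a higher number a more lipophilic compound), compound 1 gives 2 and compound 3 gives 3.1, a separation that the earlier compounds, with no single-point step between them, could not show. For this one pair, then, a clear rise in lipophilicity comes with no change beyond the scatter in the serine/threonine-protein kinase PLK2 assay, and the two compounds are told apart only in the physicochemical assay: the measured partition coefficient of compound 1, 2, and of compound 3, 3.1, a number 1.10 log units higher (beyond the scatter)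

The compounds shown leave open how this nitrogen responds to a group of a different kind, such as an amine, a carboxylic acid or a longer chain, and whether any of these would give a number clearly lower than that of compound 1. On these data alone, a single pair also cannot separate the contributions of the ring, the oxygen and the fluorines, so it remains unknown which of these, if any, matters at this position.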